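The source may hold more compounds than are shown below. What is called first, only, known or untested is meant among the compounds shown, and "the series" means these compounds.

Of the compounds shown here, three have so far been measured in a functional assay on OVCAR-3 cells (Homo sapiens) for antiproliferative activity; a lower number here means that less compound is needed, a higher number that more compound is needed for the effect. Compound 1 `O=C(Nc1cccc(S(=O)(=O)C2CCCC2)n1)c1ccc(NCCO)cc1N1CCC2(CC1)CC2` gives 117 nM, and compound 3 `CC(C)(C)NS(=O)(=O)c1cccc(NC(=O)c2ncc(NS(C)(=O)=O)nc2N2CCC3(CC2)CC3)n1` gives 32 nM. Compound 2 `O=C(Nc1cccc(S(=O)(=O)N2CCCC2)c1)c1cccnc1N1CCC2(CC1)CC2` gives 4420 nM, the highest of the three numbers and beyond the scatter from both of the others. Compound 4 `CC(C)(CO)S(=O)(=O)c1cccc(NC(=O)c2cccnc2N2CCC3(CC2)CC3)c1` has not yet been measured. It differs from compound 2 in one place: 1-(hydroxymethyl)-1-methylethyl in place of pyrrolidin-1-yl on a sulfonyl sulfur. Within the data shown here, no measured pair shows this same change, so the size of the step is uncertain. Given that compound 2 gives 4420 nM and stands apart from the others, a moderate drop in the number for compound 4 is expected rather than none or a large one. Compound 4 is expected to give about 1500 nM, within a range of 500 nM to 5000 nM, which would mean an expected step of a 2.9-fold lower number from compound 2 to compound 4 (0.47 log units; beyond the scatter) in this assay.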

Compound 4, half-maximal effective concentration: 31300 nM
Compound 4: the middle estimate sits 21-fold (1.32 log units) below what was measured; the whole stated range lies below it.
By their numbers in this assay, from the lowest: compound 3; then compound 1; then compound 2; then compound 4.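

In this assay, among these compounds, the change on the sulfonyl sulfur gives a 7.1-fold higher number from compound 2 to compound 4 (0.85 log units; beyond the scatter) and offers the first matched reading at this place, which the earlier compounds could not give. The number moves up although both groups hold 5 heavy atoms, so this place is sensitive to more than that count. Nothing available accounts for the rise. As far as these compounds go, whether the same change acts alike on the cores of compound 1 and compound 3 stays open. So does how an amine or a carboxylic acid would fare on this sulfonyl sulfur.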